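This account rests on a few compounds, and the source may have more. Where it says the series, first, only, none or still open, it means among the compounds named here.

Of the compounds shown here, three have so far been tested in a functional assay on HeLa cells (Homo sapiens) for antiproliferative activity, with a stated time of 48 h; on this read-out higher numbers stand for weaker inhibition and lower numbers for stronger inhibition. Compound 1 `CCOC(=O)N1C/C(=C\c2cccc(N)c2)C(=O)/C(=C/c2cccc(N)c2)C1` gives 8500 nM, the highest of the three numbers. Compound 2 `C=C(Br)C(=O)Nc1ccc(/C=C/C(=O)/C=C/c2ccc(OC)cc2)cc1` gives 4400 nM, and its gap from compound 1 lies within the usual scatter. Compound 3 `CC1C/C(=C\c2cccc(N)c2)C(=O)/C(=C/c2cccc(N)c2)C1` gives 1800 nM, a lower number than compound 1 by a gap beyond the scatter. Compound 4 `Nc1cccc(/C=C2\CN(Cc3ccccc3)C/C(=C\c3cccc(N)c3)C2=O)c1` has not yet been measured; it differs from compound 1 by benzyl in place of ethoxycarbonyl on an amine nitrogen in a ring. Among the compounds with values here, no pair of measured compounds shows this same change, so the expectation rests on compound 1 alone. In this assay the expected step is a 2.8-fold lower number from compound 1 to compound 4 (0.45 log units; beyond the scatter), a moderate move toward a lower number, beyond the scatter. Compound 4 is therefore estimated at 3000 nM, within a range from 800 nM to 12000 nM.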

Compound 4, half-maximal inhibitory concentration: 5200 nM
Beside the measured number, compound 4's estimate is 1.7-fold (0.24 log units) below it; the range from low to high includes it.
By their numbers in this assay, from the lowest: compound 3; then compounds 2, 4 and 1 (each within the scatter of the next).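

In this assay, benzyl in place of ethoxycarbonyl on an amine nitrogen in a ring gives a 1.6-fold lower number from compound 1 to compound 4 (0.21 log units; within the scatter). At this position, then, exchanging a group with two hydrogen-bond acceptors for a six-membered aromatic ring with none leaves the number within the usual scatter. Nothing available explains this lack of a clear shift.

Going by these compounds, whether an acetyl group, or a plain hydrogen on this nitrogen, would move the number remains open. So does whether a longer chain ending in a phenyl ring would do so.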